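This account rests on a few compounds, and the source may have more. Where it says the series, first, only, none or still open, it means among the compounds named here.

Compound 3, with structure `N#Cc1ccc(N[C@H]2CC[C@H](N(C(=O)NCc3ccccc3)c3ccccc3)CC2)nc1`, carries a plain phenyl on its urea nitrogen. In an ADME assay for permeability, read by LC-MS, using PAMPA, with a stated time of 3 h (a lower number here means that the compound crosses the layer more slowly, a higher number that the compound crosses the layer faster), compound 3 gives "not determined" (no result reported), so there is no number to place it against the other compounds. Compound 4, with structure `N#Cc1ccc(N[C@H]2CC[C@H](N(C(=O)NCc3ccccc3)c3ccc(-c4cccnc4)cc3)CC2)nc1`, differs from compound 3 by one change: pyridin-3-yl in place of hydrogen on an aromatic carbon. Two measured compounds share the rest of this scaffold and carry an aromatic ring at the same position. Compound 1, with structure `Cn1cc(-c2ccc(N(C(=O)NCc3ccccc3)[C@H]3CC[C@H](Nc4ccc(C#N)cn4)CC3)cc2)ccc1=O`, gives 273 nm/s in this assay, and compound 2, with structure `Cn1cc(-c2ccc(N(C(=O)NCc3ccccc3)[C@H]3CC[C@H](Nc4ccc(C#N)cn4)CC3)cc2)cn1`, gives 288 nm/s. The step of a 1.1-fold higher number from compound 1 to compound 2 (0.02 log units; within the scatter) shows that exchanging one such ring for another left the permeability essentially unchanged. Among the compounds with values here, no measured pair shows hydrogen replaced by an aromatic ring at this position, so the size of the step from compound 3 to compound 4 cannot be read from the data. The pyridin-3-yl of compound 4 is, however, a ring of the same kind as those in compounds 1 and 2, and a permeability close to theirs is expected for compound 4, around 280 nm/s, with a range from 140 nm/s to 560 nm/s.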

Compound 4, apparent permeability: 280 nm/s
Beside the measured number, compound 4's estimate shows no gap at the digits printed; the range from low to high includes it.
By their numbers in this assay, from the lowest: compounds 1, 4 and 2 (each within the scatter of the next).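

Pyridin-3-yl adds a third ring at this aromatic carbon, and in this assay the new steps read a 1.0-fold lower number from compound 2 to compound 4 (0.01 log units; within the scatter) and a 1.0-fold higher number from compound 1 to compound 4 (0.01 log units; within the scatter) with both inside the scatter. Across compounds 1, 2 and 4, then, three different aromatic rings at this position give no step beyond the scatter, and none of the three goes against this. No measurement on these groups is available to explain the result.

From the compounds shown here alone, the steps from compound 3 cannot be read, so the effect of adding any ring to its plain phenyl remains unknown. Going by these compounds, all three groups at this position are aromatic rings, so it remains open whether a carboxylic acid, an amine or a longer chain there would give a similar number.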